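This account rests on a few compounds, and the source may have more. Where it says the series, first, only, none or still open, it means among the compounds named here.

Compound 1 `COc1cccc2cc(C(=O)NCC(=O)O)c(=O)oc12` gives 15% in an assay on HeLa cells for displacement of a labelled ligand from adenosine receptor A3 (Homo sapiens), read by scintillation counting, with a stated time of 180 min, tested at 10 uM (on this read-out higher numbers stand for more inhibition at the one concentration tested (going by the name of the read-out) and lower numbers for less inhibition), the highest of the three numbers in hand. Compound 2 `COc1cccc2cc(C(=O)N[C@@H](CO)C(=O)O)c(=O)oc12` gives 3%, and compound 3 `COCCNC(=O)c1cc2cccc(OC)c2oc1=O` gives 0%. All three measured steps alter the chain on the amide nitrogen: a number 12 percentage points lower from compound 1 to compound 2 (beyond the scatter), a number 15 percentage points lower from compound 1 to compound 3 (beyond the scatter), and a number 3 percentage points lower from compound 2 to compound 3 (within the scatter). Compound 4 `O=C(O)CNC(=O)c1cc2ccccc2oc1=O` departs from compound 1 at a different place: hydrogen in place of methoxy on an aromatic carbon. Within the data shown here, none of the measured steps touches this part of the core, so they offer no direct guide to the loss of the methoxy group. Because compound 1 gives only 15% and the other two compounds lie lower still, all three numbers in hand are small, and a change at the aromatic carbon is expected to shift the number only a little. The step from compound 1 to compound 4 is expected to be a number 5 percentage points lower from compound 1 to compound 4 (within the scatter). Compound 4 is therefore estimated at 10%, with a range from 0% to 25%.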

Compound 4, a percentage reported as inhibition, at one concentration (the size of the read-out at that concentration, not a potency): 0%
Beside the measured number, compound 4's estimate is 10 percentage points above it; low and high end bracket the measured number.
By their numbers in this assay, from the lowest: compounds 3, 4 and 2 (each within the scatter of the next); then compound 1.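

With the amide chain of compound 1 held constant, hydrogen in place of methoxy on this aromatic carbon gives, in this assay, a number 15 percentage points lower from compound 1 to compound 4 (beyond the scatter). The earlier steps shown here changed only the chain on the amide nitrogen, whereas this one shows that the number also responds to a change on the aromatic part of the core. Compound 4 gives 0%, so the small inhibition seen with compound 1 is not kept once the methoxy group is gone, and nothing in hand gives a reason for this loss.

Going by these compounds, whether ethoxy, hydroxy or a chlorine atom on this aromatic carbon would match or exceed compound 1 remains open. On these data alone, it is also open whether methoxy has the same effect alongside other amide chains, such as 2-methoxyethyl.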